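A few compounds are considered here, and "the series" means these few. Any claim that something is new, unique, unknown or untested is made for them only; others in the source may bear on it.

In a functional assay on CNE-2 cells (Homo sapiens) for cytotoxicity, read by MTT assay, with a stated time of 3 days (on this read-out lower numbers stand for stronger inhibition and higher numbers for weaker inhibition), compound 1 `Cc1cc(C)nc(Oc2ccc(NC(=O)Nc3ccc(Cl)cc3)cc2)n1` gives 20400 nM. In this assay compound 2 `Cc1cc(C)nc(Sc2ccc(NC(=O)Nc3ccccc3)cc2)n1` gives 22000 nM. Compound 3 `Cc1cccc(NC(=O)Nc2ccc(Sc3nc(C)cc(C)n3)cc2)c1` gives > 50000 nM, which is a limit of this assay and not a number.

Compound 3 therefore stands only at that limit; its step of an at least 2.2-fold higher number from compound 2 to compound 3 (0.35 log units; beyond the scatter) shows that adding the methyl weakened inhibition. Compound 4 `Cc1cc(C)nc(Sc2ccc(NC(=O)Nc3ccc(Cl)cc3Cl)cc2)n1` differs from compound 3 by 2,4-dichlorophenyl in place of 3-methylphenyl on an amide-type nitrogen. For the measured compounds named here, the one measured step at this position is the methyl step just named, and it is undone here. Compound 1, which carries a chlorophenyl group, shows 20400 nM, and compound 2 shows 22000 nM; these two differ in two places, so only their values can be compared. The step from compound 3 to compound 4 is expected to be an at least 3.3-fold lower number from compound 3 to compound 4 (0.52 log units; beyond the scatter), toward stronger inhibition. Compound 4 is estimated at 15000 nM, within 5000 nM to 45000 nM.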

Compound 4, half-maximal inhibitory concentration: 23200 nM
The estimate for compound 4 lay 1.5-fold (0.19 log units) below the measured number, and the stated range covers the measured number.
By their numbers in this assay, from the lowest: compounds 1, 2 and 4 (each within the scatter of the next). At a limit, above all of these: compound 3.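

In this assay, 2,4-dichlorophenyl on the amide-type nitrogen brings the number back from the limit to a measured value, with an at least 2.1-fold lower number from compound 3 to compound 4 (0.33 log units; beyond the scatter). Against plain phenyl the same group shows a 1.1-fold higher number from compound 2 to compound 4 (0.02 log units; within the scatter), so the two chlorines change nothing readable here, and among these three groups only 3-methylphenyl stands apart. The first of these steps gives only a bound because compound 3 stands at a limit: the limit of > 50000 nM in this assay, at which 1 of the 4 values shown sits.

Left open is whether an amine or a carboxylic acid on this phenyl ring would bring the number any lower.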